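The compounds below may be only part of what the source reports. "The series", "measured", "known", "first", "only" and "open" are said of these compounds alone.

The measured compounds:
Compound 1, `Cc1cc(O)cc(O)c1C(=O)O[C@H]1[C@@H]2COC(/C=C/[C@H](C)O)=CC2=CC(=O)[C@@]1(C)O`: in an assay on isolated protein for inhibition of Alpha glucosidase (Homo sapiens), read by spectrophotometry, with stated times of 20 min and 1 min (on this read-out lower numbers stand for stronger inhibition and higher numbers for weaker inhibition), compound 1 gives 78600 nM.
Compound 2, `COC(=O)CCC1=CC2=CC(=O)[C@@](C)(O)[C@@H](OC(=O)c3c(C)cc(O)cc3O)[C@@H]2CO1`: in this assay compound 2 gives > 200000 nM, which is a limit of the assay and not a number.
Compound 3, `COC(=O)C1=CC2=CC(=O)[C@@](C)(O)[C@@H](OC(=O)c3c(C)cc(O)cc3O)[C@@H]2CO1`: in this assay compound 3 gives > 200000 nM, likewise a limit of the assay.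

Compound 3 thus stands at the edge of what this assay can report, sharing that position with compound 2, as the limit of > 200000 nM in this assay, at which 2 of the 3 values shown sit. Measured from compound 1, the step is an at least 2.5-fold higher number from compound 1 to compound 3 (0.40 log units; beyond the scatter), and it matches an at least 2.5-fold higher number from compound 1 to compound 2 (0.40 log units; beyond the scatter). Between the two limits the step is a step that the two limits leave unreadable from compound 2 to compound 3.

Compound 4, `COC(OC)C1=CC2=CC(=O)[C@@](C)(O)[C@@H](OC(=O)c3c(C)cc(O)cc3O)[C@@H]2CO1`, differs from compound 3 in a single place: dimethoxymethyl in place of methoxycarbonyl on a double-bonded ring carbon. Within the data shown here, none of the measured steps exchanges this kind of group; the two readable steps both swap the 3-hydroxybut-1-en-1-yl group for an ester-bearing group and both push the number past the limit. Compound 3 itself already sits at the limit, > 200000 nM, so there is no measured room on that side. Compound 4 is therefore expected to remain at or near that limit, an estimated step that the limit leaves unreadable from compound 3 to compound 4. Compound 4 is estimated at 250000 nM, expected to fall between 90000 nM and 700000 nM.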

Compound 4, half-maximal inhibitory concentration: > 200000 nM
Compound 4: no number, only a limit; the forecaster's own chance of this, stated with the estimate: 70%; the middle value lies beyond the limit too.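

The ester groups of compound 2 and compound 3 are not the whole story at this double-bonded ring carbon next to the ring oxygen: dimethoxymethyl, which holds no carbonyl, also shows an at least 2.5-fold higher number from compound 1 to compound 4 (0.40 log units; beyond the scatter). Among the compounds shown, only the 3-hydroxybut-1-en-1-yl group of compound 1 gives an actual number in this assay, while three different groups at the same place end at one reporting edge: the limit of > 200000 nM in this assay, at which 3 of the 4 values shown sit. The steps among compound 2, compound 3 and compound 4 cannot be read, so these three groups cannot be ranked against one another.

On these data alone, a plain but-1-en-1-yl chain, without the hydroxyl, would help test whether that hydroxyl or the chain with its double bond goes with the measurable value of compound 1, and this remains open. Also open, as far as these compounds go, is how an amine or a carboxylic acid at this ring carbon would read, and whether any group here could give a clearly lower number than compound 1, with its 78600 nM.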